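Cytotoxicity notes: trihalophenyl variants of the shared core

The source may report more compounds than this note shows. Statements on the series, on what has been measured and on what is new or still open speak of the compounds shown alone.

The series shares one core with a 4-cyanophenyl amine and varies only the group on an oxygen on an aromatic ring. Compound 1 `N#Cc1ccc(Nc2nc(Oc3c(Br)cc(Br)cc3Br)c3ccccc3n2)cc1` carries a 2,4,6-tribromophenyl there and in an ADME assay on MT4 cells (Homo sapiens) for cytotoxicity, read by MTT assay, with a stated time of 4 days (on this read-out higher numbers stand for lower toxicity in this test and lower numbers for higher toxicity in this test), compound 1 gives 58000 nM. Compound 2 `COc1ccc(Oc2nc(Nc3ccc(C#N)cc3)nc3ccccc23)cc1`, with a 4-methoxyphenyl, gives 340000 nM; the step is a 5.9-fold higher number from compound 1 to compound 2 (0.77 log units; beyond the scatter). Compound 3 `Cc1cc(C#N)cc(C)c1Oc1nc(Nc2ccc(C#N)cc2)nc2ccccc12`, with a 4-cyano-2,6-dimethylphenyl, gives 203000 nM, which is a 3.5-fold higher number from compound 1 to compound 3 (0.54 log units; beyond the scatter). Compound 2 and compound 3 differ by a 1.7-fold lower number from compound 2 to compound 3 (0.22 log units; within the scatter), so the two are not separable here; compound 3 holds the second highest of the three numbers, and only its gap to compound 1 lies beyond the scatter.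

Compound 4 `N#Cc1ccc(Nc2nc(Oc3c(Cl)cc(Cl)cc3Cl)c3ccccc3n2)cc1` is the next variant. Relative to compound 3 the change is 2,4,6-trichlorophenyl in place of 4-cyano-2,6-dimethylphenyl on an oxygen on an aromatic ring. Among the compounds with values here, the step that bears on it is the one from compound 1 to compound 3, which was a modest rise; compound 4 returns to a 2,4,6-trihalophenyl, so a move back toward the number of compound 1 is expected, in the direction of a lower number, of a size around that of a 3.5-fold higher number from compound 1 to compound 3 (0.54 log units; beyond the scatter) in reverse. No chlorine-for-bromine comparison exists within the series, so the expected step is a 2.5-fold lower number from compound 3 to compound 4 (0.40 log units; beyond the scatter). Compound 4 is estimated at 80000 nM, with a range from 35000 nM to 200000 nM.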

Compound 4, half-maximal cytotoxic concentration: 56000 nM
Compound 4: the middle estimate sits 1.4-fold (0.15 log units) above what was measured, and the stated range covers the measured number.
By their numbers in this assay, from the lowest: compounds 4 and 1 (each within the scatter of the next); then compounds 3 and 2 (each within the scatter of the next).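

In this assay, the new comparison of two trihalophenyl groups on an oxygen on an aromatic ring gives a 1.0-fold lower number from compound 1 to compound 4 (0.02 log units; within the scatter), so 2,4,6-trichlorophenyl and 2,4,6-tribromophenyl cannot be told apart on this read-out. The same group also stands clear of both groups without halogen, with a 3.6-fold lower number from compound 3 to compound 4 (0.56 log units; beyond the scatter) and a 6.1-fold lower number from compound 2 to compound 4 (0.78 log units; beyond the scatter), so all four compounds now fall into two groups with no exception: the trihalophenyl pair has the lower numbers, and the 4-methoxyphenyl and 4-cyano-2,6-dimethylphenyl pair has the higher numbers. No measurement on hand bears on the reason for this split.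

Open, on these data alone, is whether the lower numbers need all three halogen atoms or follow from fewer, a question that a 4-chlorophenyl or 2,4-dichlorophenyl on the same oxygen would address. Also open, as far as these compounds go, is whether the trihalophenyl result extends to 2,4,6-trifluorophenyl, and how a saturated group such as cyclohexyl on that oxygen would read in this assay.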